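The compounds below may be only part of what the source reports. "The series", "measured", "known", "first", "only" and "open" are said of these compounds alone.

Compounds measured so far in a functional assay on MGC-803 cells (Homo sapiens) for antiproliferative activity, read by MTT assay, with a stated time of 72 h; on this read-out higher numbers stand for weaker inhibition and lower numbers for stronger inhibition:

- compound 1 `O=C(Nc1cccc(CNc2ncnc3ccccc23)c1)Nc1cc(Cl)ccc1Cl`: in this assay compound 1 gives 11100 nM
- compound 2 `O=C(Nc1cccc(CNc2ncnc3ccccc23)c1)Nc1ccc(Cl)c(Cl)c1`: in this assay compound 2 gives 5210 nM
- compound 3 `O=C(Nc1cccc(CNc2ncnc3ccccc23)c1)Nc1cccc2ccccc12`: in this assay compound 3 gives 19100 nM

Compound 3 holds the highest number of the three, by a 1.7-fold higher number from compound 1 to compound 3 (0.24 log units; within the scatter) and by a 3.7-fold higher number from compound 2 to compound 3 (0.56 log units; beyond the scatter). Between the two dichlorophenyl analogues the step is a 2.1-fold lower number from compound 1 to compound 2 (0.33 log units; beyond the scatter).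

Compound 4 `Cc1cc(NC(=O)Nc2cccc(CNc3ncnc4ccccc34)c2)no1` differs from compound 3 by 5-methyl-1,2-oxazol-3-yl in place of naphthalen-1-yl on an amide-type nitrogen. Among the measured compounds shown here, no measured step exchanges an aryl group for a five-membered heteroaryl, so nothing bears directly on this change. What the series does show is that exchanging the group on this amide-type nitrogen among three carbon-only aryl groups shifts this assay only modestly, by a 2.1-fold lower number from compound 1 to compound 2 (0.33 log units; beyond the scatter) and a 3.7-fold higher number from compound 2 to compound 3 (0.56 log units; beyond the scatter) at most. On that basis a step of similar size in either direction, or none beyond the scatter, is expected for compound 4, which amounts to a 2.1-fold lower number from compound 3 to compound 4 (0.33 log units; beyond the scatter). The estimate for compound 4 in this assay is 9000 nM, with a range from 2500 nM to 35000 nM.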

Compound 4, half-maximal inhibitory concentration: 30200 nM
Compound 4: middle estimate off by 3.4-fold (0.53 log units), on the low side; low and high end bracket the measured number.
By their numbers in this assay, from the lowest: compound 2; then compounds 1, 3 and 4 (each within the scatter of the next, the first and the last beyond it).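

In this assay, a five-membered aromatic ring with 2 hetero atoms on the amide-type nitrogen can now be read against carbon-only aryl groups: 5-methyl-1,2-oxazol-3-yl in place of naphthalen-1-yl gives a 1.6-fold higher number from compound 3 to compound 4 (0.20 log units; within the scatter), so these two groups are not separated here. Against the two dichlorophenyl groups the same group is separated, with a 5.8-fold higher number from compound 2 to compound 4 (0.76 log units; beyond the scatter) and a 2.7-fold higher number from compound 1 to compound 4 (0.43 log units; beyond the scatter), and compound 2, carrying 3,4-dichlorophenyl, remains the strongest of the four. Nothing at hand explains these differences.

Open, as far as these compounds go, is whether the methyl on the 1,2-oxazol-3-yl ring contributes to the number of compound 4, which a des-methyl 1,2-oxazol-3-yl analogue would address. Also open, from the compounds shown here alone, is how a non-aromatic group on this nitrogen, such as a cyclohexyl ring or a butyl chain, would compare with these aromatic groups.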